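Indole in Place of Fluorophenyl on the Enaminone Nitrogen

The compounds below may be only part of what the source reports. "The series", "measured", "known", "first", "only" and "open" are said of these compounds alone.

Compound 1 `O=C(/C=C\Nc1ccc(F)cc1)c1nc(-c2ccc(F)cc2)n2ccccc12` was examined in a functional assay on HCT-116 cells (Homo sapiens) for cytotoxicity, read by MTT assay, with a stated time of 48 h; on this read-out lower numbers stand for stronger inhibition and higher numbers for weaker inhibition. In this assay compound 1 gives only a limit, > 30000 nM. Among the measured compounds shown here, compound 2 `O=C(/C=C\Nc1ccc(F)cc1)c1nc(-c2ccc(C(F)(F)F)cc2)n2ccccc12` is the one measured neighbour of compound 1. In this assay compound 2 likewise gives only a limit, > 30000 nM. The change of trifluoromethyl in place of fluoro on an aromatic carbon therefore corresponds to a step that the two limits leave unreadable from compound 1 to compound 2, since both values rest at the limit of > 30000 nM in this assay, at which 2 of the 2 values shown sit, and no direction can be read from them.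

Compound 3 `Cc1cc2cc(N/C=C\C(=O)c3nc(-c4ccc(F)cc4)n4ccccc34)ccc2[nH]1` has not yet been measured. It differs from compound 1 by 2-methyl-1H-indol-5-yl in place of 4-fluorophenyl on an amine nitrogen, the group entering carrying one hydrogen-bond donor. For the measured compounds named here, no measured step concerns this amine nitrogen, and the sole measured step is unreadable, so the expectation rests on the structural change alone. Compound 3 is expected to move toward stronger inhibition by an at least 6.0-fold lower number from compound 1 to compound 3 (0.77 log units; beyond the scatter), though this cannot be anchored in a measured step. Compound 3 is therefore estimated at 5000 nM, within a range from 500 nM to 30000 nM.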

Compound 3, half-maximal inhibitory concentration: > 30000 nM
Compound 3 ended at the assay's limit; the forecaster's own chance of this, stated with the estimate: 40%; middle value at least 6.0-fold (0.77 log units) from the limit.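

Compound 3, like compound 1, gives only a limit in this assay, so the step between them cannot be read, and neither can any other step among the three compounds: the limit of > 30000 nM in this assay, at which 3 of the 3 values shown sit. The compounds shown leave open how far each lies beyond that limit, and whether either change affects cytotoxicity in these cells at all.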